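This account rests on a few compounds, and the source may have more. Where it says the series, first, only, none or still open, it means among the compounds named here.

In an ADME assay on HEK293 cells (Homo sapiens) for cytotoxicity, read by MTT assay, with a stated time of 72 h (a lower number here means a stronger inhibitor, a higher number a weaker inhibitor), compound 1 `O=C(CN1CCN(C(=O)c2ccc(Br)cc2)CC1)N1CCN(CCCc2c[nH]c3ccccc23)CC1` gives 71900 nM and compound 2 `O=C(CN1CCN(C(=O)c2cccc(F)c2)CC1)N1CCN(CCCc2c[nH]c3ccccc23)CC1` gives 182000 nM, so compound 2 holds the higher of the two numbers. Compound 3 `O=C(CN1CCN(C(=O)c2ccccc2F)CC1)N1CCN(CCCc2c[nH]c3ccccc23)CC1` keeps the core of compound 2 and differs in one place: 2-fluorophenyl in place of 3-fluorophenyl on a carbonyl carbon. In words, 2-fluorophenyl stands in place of 3-fluorophenyl on a carbonyl carbon.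

Among the measured compounds shown here, only one measured step bears on this change: a 2.5-fold higher number from compound 1 to compound 2 (0.40 log units; beyond the scatter). It is modest and beyond the scatter, but it exchanges 4-bromophenyl for 3-fluorophenyl, so it is a different change from the one now in question. For the measured compounds named here, no measured pair compares 2-fluorophenyl with 3-fluorophenyl, and the direction of the coming step cannot be read from the data. In this assay, a small step is expected, quite possibly within the scatter and no larger than the one measured, with only a slight lean towards a lower number. The estimated change is a 1.2-fold lower number from compound 2 to compound 3 (0.08 log units; within the scatter). For compound 3 the expected value is 150000 nM, with an estimated range from 70000 nM to 320000 nM.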

Compound 3, half-maximal inhibitory concentration: 133000 nM
Compound 3: the middle estimate sits 1.1-fold (0.05 log units) above what was measured; low and high end bracket the measured number.
By their numbers in this assay, from the lowest: compounds 1, 3 and 2 (each within the scatter of the next, the first and the last beyond it).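

In this assay, exchanging 3-fluorophenyl for 2-fluorophenyl on a carbonyl carbon whose other neighbour is amide-type nitrogen in a ring gives a 1.4-fold lower number from compound 2 to compound 3 (0.14 log units; within the scatter) and so does not separate these two fluorophenyl groups at this position. The exchange of 4-bromophenyl for 2-fluorophenyl gives a 1.8-fold higher number from compound 1 to compound 3 (0.27 log units; within the scatter) and also stays within the scatter, whereas the step to 3-fluorophenyl, a 2.5-fold higher number from compound 1 to compound 2 (0.40 log units; beyond the scatter), lies beyond it, so leaving 4-bromophenyl does not by itself produce a step beyond the scatter in this small set, with compound 3 as the case against. No measurement on hand gives a reason for these differences.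

The compounds shown leave open how 4-fluorophenyl or 3-bromophenyl would fall, and these two groups would help to separate the identity of the halogen from where it sits on the phenyl ring. Also open, on these data alone, is whether a group without halogen at this carbonyl carbon, such as 4-methoxyphenyl, an aminophenyl or a carboxylic acid-bearing phenyl, would give a step beyond the scatter from compound 2 or compound 3.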